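Returning from a Dialkylamine to an Arylamine

The source may report more compounds than this note shows. Statements on the series, on what has been measured and on what is new or still open speak of the compounds shown alone.

Compound 1 `O=C1C(Nc2cccc(Cl)c2)=CC(=O)c2c1nc1n2[C@H]2OC[C@@H](O)[C@H]2OC1` gives 3080 nM in a functional assay on ECa-109 cells for inhibition, with ECa-109 cell line (Homo sapiens) as the target, read by sulforhodamine B assay; on this read-out higher numbers stand for weaker inhibition and lower numbers for stronger inhibition.
Compound 2 `O=C1C(Nc2ccccc2F)=CC(=O)c2c1nc1n2[C@H]2OC[C@@H](O)[C@H]2OC1` gives 2660 nM in this assay.
Compound 3 `CCCN(CCC)C1=CC(=O)c2c(nc3n2[C@H]2OC[C@@H](O)[C@H]2OC3)C1=O` gives > 16000 nM in this assay, which is a limit of this assay and not a number.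

Compound 3 thus stands at the limit of > 16000 nM in this assay, at which 1 of the 3 values shown sits, the weakest reading among the three. Compound 4 `O=C1C(Nc2cccc(F)c2)=CC(=O)c2c1nc1n2[C@H]2OC[C@@H](O)[C@H]2OC1` differs from it by (3-fluorophenyl)amino in place of dipropylamino on a double-bonded ring carbon. Among the measured compounds shown here, two measured steps bear on this change, each run in the opposite direction: an at least 5.1-fold higher number from compound 1 to compound 3 (0.71 log units; beyond the scatter), and an at least 6.0-fold higher number from compound 2 to compound 3 (0.77 log units; beyond the scatter). Reversing the same kind of exchange should therefore bring compound 4 back to a lower number by at least a modest step, into the region where compound 1 and compound 2 sit. Compound 4 is accordingly expected at about 2900 nM, with a range from 1400 nM to 6500 nM, an estimated step of an at least 5.5-fold lower number from compound 3 to compound 4 (0.74 log units; beyond the scatter).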

Compound 4, half-maximal inhibitory concentration: 2370 nM
Beside the measured number, compound 4's estimate is 1.2-fold (0.09 log units) above it; low and high end bracket the measured number.
By their numbers in this assay, from the lowest: compounds 4, 2 and 1 (each within the scatter of the next). At a limit, above all of these: compound 3.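

On the double-bonded ring carbon, (3-fluorophenyl)amino in place of dipropylamino gives an at least 6.7-fold lower number from compound 3 to compound 4 (0.82 log units; beyond the scatter) in this assay, so a third arylamine falls in the same region as the first two. Swapping the halogen or its ring position changes little here, with a 1.1-fold lower number from compound 2 to compound 4 (0.05 log units; within the scatter) and a 1.3-fold lower number from compound 1 to compound 4 (0.11 log units; within the scatter). Compound 3 remains a limit of the assay and not a number: the limit of > 16000 nM in this assay, at which 1 of the 4 values shown sits.

From the compounds shown here alone, whether an unsubstituted phenylamino or a methoxyphenylamino group would read the same stays open. So does whether a shorter dialkylamine such as dimethylamino or an N-methylated arylamine would behave like dipropylamino.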